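The source may hold more compounds than are shown below. What is called first, only, known or untested is meant among the compounds shown, and "the series" means these compounds.

Measured in a functional assay on HeLa cells (Homo sapiens) for cytotoxicity, read by neutral red uptake, with a stated time of 3 days; on this read-out lower numbers stand for stronger inhibition and higher numbers for weaker inhibition:
Compound 1 `Cc1c(F)c(N)c2c(=O)cc(-c3ccc(N)c(F)c3)oc2c1F`: > 100000 nM (a limit)
Compound 2 `CCc1c(F)c(N)c2c(=O)cc(-c3ccc(N)c(F)c3)oc2c1F`: > 100000 nM (a limit)
Compound 3 `CCCCCCc1c(F)c(N)c2c(=O)cc(-c3ccc(N)c(F)c3)oc2c1F`: 21000 nM

Compound 3 alone gives a true number, and the other two compounds rest on (the limit of > 100000 nM in this assay, at which 2 of the 3 values shown sit). Compound 4 `COc1c(F)c(N)c2c(=O)cc(-c3ccc(N)c(F)c3)oc2c1F` keeps the shared core but differs at one place: methoxy in place of hexyl on an aromatic carbon. The measured steps that bear on this are an at least 4.7-fold lower number from compound 1 to compound 3 (0.67 log units; beyond the scatter) and an at least 4.7-fold lower number from compound 2 to compound 3 (0.67 log units; beyond the scatter), both of which reach compound 3 by lengthening the chain, while a step that the two limits leave unreadable from compound 1 to compound 2 says little. For the measured compounds named here, no measured step tests a methoxy group, so the expectation is loose. With the hexyl gone, the gain seen in an at least 4.7-fold lower number from compound 2 to compound 3 (0.67 log units; beyond the scatter) is expected to be lost, giving an expected 4.8-fold higher number from compound 3 to compound 4 (0.68 log units; beyond the scatter). For compound 4 the estimate is 100000 nM, within an expected range of 40000 nM to 250000 nM.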

Compound 4, half-maximal inhibitory concentration: 34000 nM
Compound 4: the middle estimate sits 2.9-fold (0.47 log units) above what was measured; the measured number lies below the stated range.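

In this assay, replacing hexyl with methoxy on this aromatic carbon gives a 1.6-fold higher number from compound 3 to compound 4 (0.21 log units; within the scatter), so a measurable reading here does not depend on the long chain. The methoxy group also separates compound 4 from the compounds with shorter carbon groups, with an at least 2.9-fold lower number from compound 2 to compound 4 (0.46 log units; beyond the scatter) and an at least 2.9-fold lower number from compound 1 to compound 4 (0.46 log units; beyond the scatter). Both of these steps start from a limit, not a number: the limit of > 100000 nM in this assay, at which 2 of the 4 values shown sit.

From the compounds shown here alone, whether an ethoxy group, a hydroxyl group or a dimethylamino group on this carbon would read like methoxy remains open. So does how the reading changes for a propyl or butyl chain, which would fall between ethyl and hexyl.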